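This account rests on a few compounds, and the source may have more. Where it says the series, first, only, none or still open, it means among the compounds named here.

Measured in a functional assay on PC-3 cells (Homo sapiens) for cytotoxicity, read by sulforhodamine B assay, with a stated time of 5 days; on this read-out lower numbers stand for stronger inhibition and higher numbers for weaker inhibition:
- Compound 1 `O=C(CCCCCCCCCCc1ccccc1)CC(=O)N[C@H]1CCOC1=O`: 2000 nM
- Compound 2 `O=C(CCCCCCCCCc1ccccc1)CC(=O)N[C@@H]1CCOC1=O`: > 100000 nM

Going by these compounds, for compound 2, > 100000 nM is a limit of the assay and not a number, so its true position is unknown. Going by the values given here, compound 3 `O=C(CCCCCCCCCc1ccccc1)CC(=O)N[C@H]1CCOC1=O` alters only one feature of compound 2: the two compounds have the same atoms and bonds and differ only in configuration as drawn: 1 of 1 stereo elements differ; a stereocentre at a saturated ring carbon is drawn R in compound 2 and S in compound 3. Compound 3 is expected to give a true number in this assay because compound 1 gives 2000 nM. The expected change is large and towards stronger inhibition: an at least 20-fold lower number from compound 2 to compound 3 (1.30 log units; beyond the scatter). Compound 3 is estimated at 5000 nM, with an expected range of 1500 nM to 20000 nM.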

Compound 3, half-maximal inhibitory concentration: 4000 nM
Compound 3: middle estimate off by 1.3-fold (0.10 log units), on the high side; measured number inside the range.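

In this assay, the stereocentre at the saturated ring carbon proves decisive: with nothing else altered, drawing it S instead of R gives an at least 25-fold lower number from compound 2 to compound 3 (1.39 log units; beyond the scatter). That step rests on a limit for compound 2, which is not a true number: the limit of > 100000 nM in this assay, at which 1 of the 3 values shown sits. Along the chain, phenyl in place of benzyl gives a 2.0-fold higher number from compound 1 to compound 3 (0.30 log units; within the scatter), so this small shortening leaves no readable difference.

Going by these compounds, whether a much shorter chain would hold this level remains open. So does the effect of a carboxylic acid or an amine at the chain end in place of the phenyl ring.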